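Acyl variation on the N-benzyl trimethoxyanilide series

The source may report more compounds than this note shows. Statements on the series, on what has been measured and on what is new or still open speak of the compounds shown alone.

Measured so far:
compound 1 `COc1ccc(CN(C(=O)C=C(C)C)c2cc(OC)c(OC)c(OC)c2)cc1O` — 320 nM
compound 2 `C/C=C/C=C/C(=O)N(Cc1ccc(OC)c(O)c1)c1cc(OC)c(OC)c(OC)c1` — 140 nM

In a functional assay on MGC-803 cells (Homo sapiens) for inhibition, read by MTT assay, with a stated time of 48 h (a lower number here means a stronger inhibitor, a higher number a weaker inhibitor), compound 2 stands lowest of the two numbers; its nearest neighbour is compound 1, and the step of a 2.3-fold lower number from compound 1 to compound 2 (0.36 log units; beyond the scatter) lies beyond the scatter. Compound 3 `COc1ccc(CN(C(=O)C(C)C)c2cc(OC)c(OC)c(OC)c2)cc1O` differs from compound 2 in one place: isopropyl in place of penta-1,3-dien-1-yl on a carbonyl carbon. For the measured compounds named here, the only step that bears on it is a 2.3-fold lower number from compound 1 to compound 2 (0.36 log units; beyond the scatter), where the longer unsaturated chain gave the lower number. Compound 3 carries the shortest chain of the three, without double bonds, so a higher number is expected, estimated as a 4.3-fold higher number from compound 2 to compound 3 (0.63 log units; beyond the scatter). The estimate for compound 3 in this assay is 600 nM, within 250 nM to 1500 nM.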

Compound 3, half-maximal inhibitory concentration: 210 nM
Compound 3: middle estimate off by 2.9-fold (0.46 log units), on the high side; measured number below the stated range.
By their numbers in this assay, from the lowest: compounds 2, 3 and 1 (each within the scatter of the next, the first and the last beyond it).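

In this assay the change to isopropyl gives a 1.5-fold higher number from compound 2 to compound 3 (0.18 log units; within the scatter) and a 1.5-fold lower number from compound 1 to compound 3 (0.18 log units; within the scatter), so the saturated group cannot be told apart from either unsaturated chain on this carbonyl carbon. The order of longer unsaturated chain before shorter one, seen between compound 1 and compound 2, therefore does not extend to a simple trend with chain size or double bonds. No supporting measurement bears on this result.

Still open, going by these compounds, is whether a longer saturated chain, a phenyl ring or an amine on the acyl group would move the number beyond the scatter.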